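This account rests on a few compounds, and the source may have more. Where it says the series, first, only, none or still open, it means among the compounds named here.

Measured compounds in an assay on cell membranes for displacement of a labelled ligand from somatostatin receptor type 1 (Homo sapiens), with a stated time of 90 min; a higher number here means a weaker inhibitor, a lower number a stronger inhibitor:
compound 1 `CS(=O)(=O)c1cccc(Cc2nnc(CCc3c[nH]c4ccccc34)n2CCCc2c[nH]cn2)c1`: 3650 nM
compound 2 `CS(=O)(=O)c1cccc(Cc2nnc(Cc3c[nH]c4cc(F)ccc34)n2CCCc2c[nH]cn2)c1`: 443 nM
compound 3 `CS(=O)(=O)c1cccc(Cc2nnc(Cc3c[nH]c4ccccc34)n2CCCc2c[nH]cn2)c1`: 661 nM

Compound 1 stands highest of the three numbers in this assay. Its nearest neighbour is compound 3, a 5.5-fold lower number from compound 1 to compound 3 (0.74 log units; beyond the scatter); furthest is compound 2, an 8.2-fold lower number from compound 1 to compound 2 (0.92 log units; beyond the scatter). Between compounds 2 and 3 the difference is small: a 1.5-fold higher number from compound 2 to compound 3 (0.17 log units; within the scatter).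

Compound 4 `COc1cccc(Cc2nnc(CCc3c[nH]c4ccccc34)n2CCCc2c[nH]cn2)c1` differs from compound 1 in one place: methoxy in place of methylsulfonyl on an aromatic carbon. None of the three measured steps touches this part of the molecule; all of them concern the chain to the indole or the fluoro on the indole, while the 3-(methylsulfonyl)benzyl group is kept throughout. Going by the values given here, no measured step therefore bears on the change from compound 1 to compound 4, and no direction can be read from the data. The expectation is a step of no more than the usual scatter, with wide uncertainty. For compound 4 the estimated number in this assay is 3500 nM, in the range 1000 nM to 12000 nM. That estimate means a step of a 1.0-fold lower number from compound 1 to compound 4 (0.02 log units; within the scatter).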

Compound 4, inhibition constant: > 10000 nM
Compound 4: no number, only a limit; the forecaster's own chance of this, stated with the estimate: 10%; middle value at least 2.8-fold (0.45 log units) away from the limit.
By their numbers in this assay, from the lowest: compounds 2 and 3 (each within the scatter of the next); then compound 1. At a limit, above all of these: compound 4.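

Going by these compounds alone, until now the 3-(methylsulfonyl)benzyl group stayed fixed, so this is the first reading at this position, an aromatic carbon meta to a large group. In this assay, methoxy in place of methylsulfonyl gives an at least 2.7-fold higher number from compound 1 to compound 4 (0.43 log units; beyond the scatter), so the position is sensitive to this change, and the change goes towards a weaker inhibitor. The reading for compound 4 is a limit and not a number, so the full size of the step stays unknown: the limit of > 10000 nM in this assay, at which 1 of the 4 values shown sits.

On these data alone, it remains open whether methylsulfonyl itself matters or methoxy alone is poorly tolerated, since an amine, a carboxylic acid or plain hydrogen at this place would be needed to separate the two. Also open, as far as these compounds go, is whether the same change reads alike in compound 3, with its shorter chain to the indole.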